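Replacing the Nitrooxyphenyl Hydrazone with a Difluorophenyl

The compounds below may be only part of what the source reports. "The series", "measured", "known", "first", "only" and "open" are said of these compounds alone.

Compound 1, `CN(C)CCn1cnnc1-c1cc(Oc2ccc(NC(=O)N/N=C/c3c(Cl)cccc3Cl)cc2F)ccn1`: in a functional assay on U-87MG ATCC cells (Homo sapiens) for cytotoxicity, read by MTT assay, with a stated time of 72 h (on this read-out higher numbers stand for weaker inhibition and lower numbers for stronger inhibition), compound 1 reaches only the limit of > 100000 nM.
Compound 2, `COc1ccc(/C=N/NC(=O)Nc2ccc(Oc3ccnc(-c4nncn4CCN(C)C)c3)c(F)c2)c(OC)c1`: in this assay compound 2 gives 12600 nM.
Compound 3, `CN(C)CCn1cnnc1-c1cc(Oc2ccc(NC(=O)N/N=C/c3ccccc3O[N+](=O)[O-])cc2F)ccn1`: in this assay compound 3 gives 7150 nM.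

Compound 3 holds the lowest of the two real numbers in this assay; compound 2 sits nearest, with a 1.8-fold lower number from compound 2 to compound 3 (0.25 log units; within the scatter), so the two are not separated. The third value, that of compound 1, is a limit of the assay (the limit of > 100000 nM in this assay, at which 1 of the 3 values shown sits), not a number.

Compound 4, `CN(C)CCn1cnnc1-c1cc(Oc2ccc(NC(=O)N/N=C/c3ccc(F)cc3F)cc2F)ccn1`, has not yet been measured. It differs from compound 3 in one place: 2,4-difluorophenyl in place of 2-(nitrooxy)phenyl on a carbon with a double bond to nitrogen. For the measured compounds named here, two measured steps bear on this change, both at the same carbon. The step of an at least 13-fold lower number from compound 1 to compound 3 (1.14 log units; beyond the scatter) shows that moving from a dichlorinated phenyl to the nitrooxyphenyl brought a large drop in the number, and the step of an at least 7.9-fold lower number from compound 1 to compound 2 (0.89 log units; beyond the scatter) shows a similar gain for a dimethoxyphenyl. The step of a 1.8-fold lower number from compound 2 to compound 3 (0.25 log units; within the scatter) shows two oxygen-bearing phenyls behaving alike. Compound 4 returns to a halogenated phenyl, though with a different pattern of substitution from compound 1.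

On this basis compound 4 is expected to give a higher number than compound 3, with a 3.5-fold higher number from compound 3 to compound 4 (0.54 log units; beyond the scatter), estimated at 25000 nM in this assay, within a range from 5000 nM to 100000 nM.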

Compound 4, half-maximal inhibitory concentration: 1900 nM
Estimate against measurement, compound 4: 13-fold (1.12 log units) above, outside the stated range (below it).
By their numbers in this assay, from the lowest: compound 4; then compounds 3 and 2 (each within the scatter of the next). At a limit, above all of these: compound 1.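

The 2,4-difluorophenyl on the carbon with a double bond to nitrogen does what neither oxygen-bearing phenyl did, with a 3.8-fold lower number from compound 3 to compound 4 (0.58 log units; beyond the scatter) and a 6.6-fold lower number from compound 2 to compound 4 (0.82 log units; beyond the scatter), so the earlier pair, which the scatter did not separate, did not mark the best that this position can give. A halogenated phenyl at this place is therefore no liability in itself, since in this assay the two halogenated compounds lie at opposite ends of the series, with an at least 52-fold lower number from compound 1 to compound 4 (1.72 log units; beyond the scatter). The size of that last step has only a lower bound, as compound 1 has a limit and not a number: the limit of > 100000 nM in this assay, at which 1 of the 4 values shown sits.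

Compound 1 and compound 4 differ in both the halogen and its pattern on the phenyl, so the compounds shown cannot say which of the two accounts for the gap between them. Also open, from the compounds shown here alone, is where an unsubstituted phenyl, a phenyl with a single fluorine, or a phenyl bearing an amine or a carboxylic acid would fall at this position.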